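The compounds below may be only part of what the source reports. "The series", "measured", "known", "first", "only" and "open" are said of these compounds alone.

Measured so far in a functional assay on SN12C cells (Homo sapiens) for inhibition, read by sulforhodamine B assay, with a stated time of 48 h, tested at 10 uM; a higher number here means more inhibition of growth at the concentration tested, a lower number less inhibition of growth

Compound 1 `COc1ccc(-c2nc3sc(-c4ccccc4)cn3n2)cc1` gives 37%
Compound 2 `COc1cc(-c2nc3sc(-c4ccccc4)cn3n2)cc(OC)c1OC` gives 19%
Compound 3 `COc1cc(-c2nc(N)n(CC(=O)Nc3ccc(/C(C)=N\O)cc3)n2)cc(OC)c1OC` gives 4%

Compound 1 has the highest number of the three, and both compound 2 and compound 3 lie lower by more than the usual scatter of repeated measurements. The next compound to consider is compound 4 `COc1ccc(-c2nc3sc(-c4ccc(Cl)cc4)cn3n2)cc1`, which is compound 1 with one change. It has chloro in place of hydrogen on an aromatic carbon, para to a large group, so that phenyl becomes 4-chlorophenyl (chloro in place of hydrogen on an aromatic carbon).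

Going by the values given here, no two measured compounds differ in one place only, and nothing here shows directly what this change does in this assay as a result. The natural starting point is compound 1 at 37% as the closest measured relative. Compound 1 and compound 2 (19%) share a core and still lie well apart, which argues for a wide range. The expected step is a small rise that stays within the usual scatter, a number 5 percentage points higher from compound 1 to compound 4 (within the scatter) as estimated. For compound 4 the estimated value is 42% with an expected range from 22% to 65% as the likely span of a measurement.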

Compound 4, percent growth inhibition at one concentration: 94.7%
Compound 4: middle estimate off by 52.7 percentage points, on the low side; the whole stated range lies below it.
By their numbers in this assay, from the lowest: compound 3; then compound 2; then compound 1; then compound 4.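

In this assay, going by these compounds alone, this is the first pair of compounds that differ in one place, so the effect of a change can be read directly: a number 57.7 percentage points higher from compound 1 to compound 4 (beyond the scatter). This large step comes from a single added chlorine atom, with the rest of the molecule unchanged, as phenyl becomes 4-chlorophenyl, so what sits on this aromatic carbon, para to a large group, matters greatly for growth inhibition at the concentration tested. Nothing available here accounts for the size of this step.

The compounds shown leave open whether the chlorine itself is needed, since they do not say whether fluoro, bromo, methyl or an amine at the same place would give a similar rise or none at all. They also leave open whether chloro in place of hydrogen at this position would raise the number of compound 2 as well, or whether the rise belongs only to the setting of compound 1.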